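A hydroxycyclobutyl end on the amide chain of compound 3

A few compounds are considered here, and "the series" means these few. Any claim that something is new, unique, unknown or untested is made for them only; others in the source may bear on it.

Measured in an in vitro ADME assay on microsomes from Gut (Homo sapiens) for metabolic stability, using NADPH; a higher number here means faster removal of the compound, a lower number slower removal:
Compound 1 `COc1ccc(OC(F)(F)F)cc1Cn1c(C(=O)NCC(C)(C)CO)cc2cc(C#N)ccc21` gives < 6 mL.min-1.g-1
Compound 2 `Cc1ccc(C)c(Cn2c(C(=O)NCC(C)(C)CO)cc3cc(C#N)ccc32)c1` gives < 6 mL.min-1.g-1
Compound 3 `CC(C)(O)CCNC(=O)c1cc2cc(C#N)ccc2n1Cc1cccc(OC(F)(F)F)c1` gives < 6 mL.min-1.g-1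

All three entries are limits of the assay and not numbers, and the record shows the limit of < 6 mL.min-1.g-1 in this assay, at which 3 of the 3 values shown sit, for this small set. Compound 3 stands at < 6 mL.min-1.g-1 in this assay, which is a limit and gives it no number of its own. Among the compounds with values here, no step between measured compounds is available.

Compound 4 `N#Cc1ccc2c(c1)cc(C(=O)NCCC1(O)CCC1)n2Cc1cccc(OC(F)(F)F)c1` keeps the shared core and changes the end of the amide chain: 1-hydroxycyclobutyl in place of 1-hydroxy-1-methylethyl on a saturated chain carbon, two bonds along the chain from an amide-type nitrogen. In words, this is 1-hydroxycyclobutyl in place of 1-hydroxy-1-methylethyl on a saturated chain carbon, two bonds along the chain from an amide-type nitrogen.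

With nothing measured to size such a change, the expected result is no shift beyond the scatter, an estimated step that the limit leaves unreadable from compound 3 to compound 4 in this assay, and the assay may well report only a limit again. For compound 4 the estimate is 5 mL.min-1.g-1, with an expected range from 3 mL.min-1.g-1 to 10 mL.min-1.g-1 in the measurement to come.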

Compound 4, intrinsic clearance in microsomes: < 6 mL.min-1.g-1
Compound 4: only a limit was reported; the forecaster's own chance of this, stated with the estimate: 75%; the middle value lies beyond the limit too.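

Within the data shown here, compound 3 and compound 4 are both reported only as limits in this assay, and no step between them can be read. The compounds shown leave open how fast each is actually removed, and whether 1-hydroxycyclobutyl differs from 1-hydroxy-1-methylethyl at all: the limit of < 6 mL.min-1.g-1 in this assay, at which 4 of the 4 values shown sit.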